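A few compounds are considered here, and "the series" means these few. Any claim that something is new, unique, unknown or untested is made for them only; others in the source may bear on it.

Measured compounds:
compound 1 `CC(C)(C)NCc1c(C(=O)O)nn(-c2ccccc2)c1-c1ccc(Br)cc1` — 293000 nM
compound 2 `CC(C)(C)NCc1c(C(=O)O)nn(-c2ccccc2)c1-c1ccccc1` — > 716000 nM
compound 3 `CC(C)(C)NCc1c(C(=O)O)nn(-c2ccc(Cl)cc2)c1-c1ccc(Br)cc1` — 221000 nM

All three were tested in a functional assay on MCF7 cells (Homo sapiens) for inhibition, read by sulforhodamine B assay, with a stated time of 48 h; a lower number here means a stronger inhibitor of growth, a higher number a weaker inhibitor of growth. For compound 2 the value is only a limit of this assay, not a number, (the limit of > 716000 nM in this assay, at which 1 of the 3 values shown sits). Compound 3 differs from compound 1 in its core by chloro in place of hydrogen on an aromatic carbon, and the step of a 1.3-fold lower number from compound 1 to compound 3 (0.12 log units; within the scatter) is small. The change hydrogen in place of bromo on an aromatic carbon gave an at least 2.4-fold higher number from compound 1 to compound 2 (0.38 log units; beyond the scatter), a step that reaches the limit. Compound 4 `CC(C)(C)NCc1c(C(=O)O)nn(-c2ccc(Cl)cc2)c1-c1ccccc1`, still to be measured, arises from compound 3 by the same change, (hydrogen in place of bromo on an aromatic carbon). Because an at least 2.4-fold higher number from compound 1 to compound 2 (0.38 log units; beyond the scatter) ran up to the limit, a step of similar size is expected from compound 3 to compound 4, a 2.7-fold higher number from compound 3 to compound 4 (0.43 log units; beyond the scatter). Compound 4 is therefore estimated at 600000 nM in this assay, expected between 350000 nM and 1200000 nM, with a fair chance that only a limit is reported.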

Compound 4, concentration for 50% growth inhibition: 496000 nM
Compound 4: middle estimate off by 1.2-fold (0.08 log units), on the high side; measured number inside the range.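

In this assay, the change from 4-bromophenyl to phenyl gave a 2.2-fold higher number from compound 3 to compound 4 (0.35 log units; beyond the scatter), so the number rose on both cores tested: the same change on two cores in this assay, an at least 2.4-fold higher number (0.38 log units; beyond the scatter) from compound 1 to compound 2 and a 2.2-fold higher number (0.35 log units; beyond the scatter) from compound 3 to compound 4; the limit leaves it open whether they differ. This shows that the direction of the change carried over from one core to the other, but only for these two cores, and the value of compound 2, > 716000 nM, is a limit of the assay and not a number, so it does not show that the step has the same size on both. The chloro change, read on the phenyl compounds, gave an at least 1.4-fold lower number from compound 2 to compound 4 (0.15 log units; that floor lies within the scatter), and this too starts from that limit: the same change on two cores in this assay, a 1.3-fold lower number (0.12 log units; within the scatter) from compound 1 to compound 3 and an at least 1.4-fold lower number (0.15 log units; that floor lies within the scatter) from compound 2 to compound 4; the limit leaves it open whether they differ.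

The compounds shown leave open whether fluoro, methyl or methoxy in the place of bromo would act as bromo does. They also leave open what an ester or an amide in the place of the carboxylic acid would give.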